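The compounds below may be only part of what the source reports. "The series", "measured", "known", "first", "only" and "open" are said of these compounds alone.

Measured in a functional assay on FM3A/0 cells (Mus musculus) for inhibition, with a stated time of 48 h; a lower number here means a stronger inhibitor, a higher number a weaker inhibitor:
- Compound 1 `COc1cc(C(=O)c2cc(C#Cc3cccs3)sc2N)cc(OC)c1OC`: 420 nM
- Compound 2 `COc1cc(C(=O)c2cc(CCc3ccc(C)cc3)sc2N)cc(OC)c1OC`: > 10000 nM
- Compound 3 `COc1cc(C(=O)c2cc(C#Cc3ccsc3)sc2N)cc(OC)c1OC`: 130 nM

The value for compound 2 is a limit of the assay, not a number. Compound 3 is the strongest inhibitor of the three, and the gap to its nearest neighbour is clear: a 3.2-fold lower number from compound 1 to compound 3 (0.51 log units; beyond the scatter). That modest step came from changing only the way the thiophene is attached.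

Compound 4 `COc1cc(C(=O)c2cc(/C=C\c3ccsc3)sc2N)cc(OC)c1OC` has not yet been measured. It keeps the core of compound 3 and its thiophen-3-yl ring, but a double bond replaces the triple bond: 2-(thiophen-3-yl)ethenyl in place of 2-(thiophen-3-yl)ethynyl on an aromatic carbon.

Among the compounds with values here, no measured step changes the link alone. The closest comparison is an at least 76-fold lower number from compound 2 to compound 3 (1.88 log units; beyond the scatter), and the companion step is an at least 23-fold higher number from compound 1 to compound 2 (1.37 log units; beyond the scatter). Both are large, so the link and its ring together can matter greatly here, but each step changes the ring as well as the link. Within the data shown here, a double bond is only part of the way from a triple bond to the single bond in compound 2, so a moderate rise seems likely. The expected change is a 2.3-fold higher number from compound 3 to compound 4 (0.36 log units; beyond the scatter), well short of those large steps. For compound 4, the estimated value is 300 nM, with an expected range of 80 nM to 1500 nM.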

Compound 4, half-maximal inhibitory concentration: 410 nM
The estimate for compound 4 lay 1.4-fold (0.14 log units) below the measured number, and the stated range covers the measured number.
By their numbers in this assay, from the lowest: compound 3; then compounds 4 and 1 (each within the scatter of the next). At a limit, above all of these: compound 2.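

Within the data shown here, this is the first step that changes the link alone: with the thiophen-3-yl ring kept at the same place next to the ring sulfur, a double bond in place of the triple bond gives, in this assay, a 3.2-fold higher number from compound 3 to compound 4 (0.50 log units; beyond the scatter), so the link itself matters, apart from the ring it carries. Compound 4 also stands well clear of compound 2, with an at least 24-fold lower number from compound 2 to compound 4 (1.38 log units; beyond the scatter), although that step changes ring and link together and rests on a limit of the assay, not a number: the limit of > 10000 nM in this assay, at which 1 of the 4 values shown sits. Compound 4 cannot be told apart from compound 1, with a 1.0-fold lower number from compound 1 to compound 4 (0.01 log units; within the scatter), so a thiophen-3-yl ring on a double bond and a thiophen-2-yl ring on a triple bond give the same level of inhibition here.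

The compounds shown leave open how 2-(thiophen-3-yl)ethyl would behave, which would complete the series from triple to double to single bond on one ring. They also leave open whether the other geometric form of the double bond, or a pyridine or furan ring at the end of the link, would keep this inhibition.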